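The source may report more compounds than this note shows. Statements on the series, on what has been measured and on what is new or still open speak of the compounds shown alone.

Compound 2 `Cc1ccccc1N1CCN(C(=S)SCc2ccc3nc(N)nc(N)c3c2)CC1` is the reference point of this step. Within the data shown here, in a functional assay on A549 cells (Homo sapiens) for antiproliferative activity, read by MTT assay, with a stated time of 72 h (on this read-out higher numbers stand for weaker inhibition and lower numbers for stronger inhibition), compound 2 gives 3920 nM, the highest of the three numbers measured so far. Compound 1 `COc1ccc(N2CCN(C(=S)SCc3ccc4nc(N)nc(N)c4c3)CC2)cc1` gives 1590 nM in this assay, and compound 3 `Nc1nc(N)c2cc(CSC(=S)N3CCN(c4ccc(Cl)c(Cl)c4)CC3)ccc2n1` gives 2940 nM. Of the measured steps only a 2.5-fold higher number from compound 1 to compound 2 (0.39 log units; beyond the scatter) lies beyond the scatter; a 1.3-fold lower number from compound 2 to compound 3 (0.12 log units; within the scatter) and a 1.8-fold higher number from compound 1 to compound 3 (0.27 log units; within the scatter) both sit within it. All three exchanges replace the aryl group on an amine nitrogen in a ring while the rest of the molecule stays the same.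

Compound 4 `Nc1nc(N)c2cc(CSC(=S)N3CCN(c4ccccc4[N+](=O)[O-])CC3)ccc2n1` carries the change (nitro in place of methyl on an aromatic carbon). Among the measured compounds shown here, no measured step exchanges a methyl for a nitro, and none alters a substituent ortho to a large group; the measured steps bear on it only in showing that changing the aryl substituent has moved this assay by modest amounts or not beyond the scatter. A step within the scatter, or at most a modest one in either direction, is therefore expected. For compound 4 the expected step is a 1.2-fold lower number from compound 2 to compound 4 (0.09 log units; within the scatter). Compound 4 is estimated at 3200 nM, with a range from 1300 nM to 8000 nM.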

Compound 4, half-maximal inhibitory concentration: 4360 nM
Compound 4: the middle estimate sits 1.4-fold (0.13 log units) below what was measured, within the range that was stated.
By their numbers in this assay, from the lowest: compounds 1, 3, 2 and 4 (each within the scatter of the next, the first and the last beyond it).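

In this assay, nitro in place of methyl on an aromatic carbon, ortho to a large group, gives a 1.1-fold higher number from compound 2 to compound 4 (0.05 log units; within the scatter), so this position tolerates the exchange of methyl for a group carrying hydrogen-bond acceptors with no step beyond the scatter. The exchange of 3,4-dichlorophenyl for 2-nitrophenyl also stays within the scatter (a 1.5-fold higher number from compound 3 to compound 4 (0.17 log units; within the scatter)), while the exchange of 4-methoxyphenyl for 2-nitrophenyl gives a modest step beyond it (a 2.7-fold higher number from compound 1 to compound 4 (0.44 log units; beyond the scatter)). Compound 1 thus stands apart from compound 2 and compound 4, but not from compound 3. On these data alone, it remains open whether an amine or a carboxylic acid on the same aromatic carbon would give a step beyond the scatter, and whether nitro elsewhere on the ring would. No measurement shown explains these small steps.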